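The source may report more compounds than this note shows. Statements on the series, on what has been measured and on what is new or still open speak of the compounds shown alone.

Working notes on the series. Compound 1 `Fc1ccc(-c2nn(-c3ccccc3)cc2-c2nc3ccccc3[nH]2)cc1`, compound 2 `Clc1ccc(-c2nn(-c3ccccc3)cc2-c2nc3ccccc3[nH]2)cc1` and compound 3 `Fc1ccc2[nH]c(-c3cn(-c4ccccc4)nc3-c3ccc(Cl)cc3)nc2c1` have been run in a functional assay on MCF7 cells (Homo sapiens) for antiproliferative activity, read by MTT assay, with a stated time of 48 h; a lower number here means a stronger inhibitor, a higher number a weaker inhibitor. Compound 1 gives 3200 nM in this assay. Compound 2 gives 3030 nM, and a 1.1-fold lower number from compound 1 to compound 2 (0.02 log units; within the scatter). The difference between compound 1 and compound 2 is chloro in place of fluoro on an aromatic carbon. Compound 3 gives 2830 nM in this assay, and a 1.1-fold lower number from compound 2 to compound 3 (0.03 log units; within the scatter). Compound 3 and compound 1 differ in more than one place, and the difference between the two cores is not broken down here. All three numbers lie within the scatter of one another, so no order among them is claimed.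

Compound 4 `Clc1ccc(-c2nn(-c3ccccc3)cc2-c2nc3cc(Cl)ccc3[nH]2)cc1` has not yet been measured in this assay. It differs from compound 3 by chloro in place of fluoro on an aromatic carbon. Within the data shown here, this is the same kind of change as the one from compound 1 to compound 2, though the place is not the same: in compound 1 the fluoro sits on a six-membered aromatic ring of carbon only, para to a large group, whereas in compound 3 it sits on a six-membered aromatic ring of carbon only that is part of a fused or bridged system of two rings, meta to a fused ring and para to a fused ring. Among the compounds shown the change occurs twice, once measured and once pending.

The step from compound 3 to compound 4 in this assay is expected to be a 1.0-fold lower number from compound 3 to compound 4 (0.00 log units; within the scatter), because a 1.1-fold lower number from compound 1 to compound 2 (0.02 log units; within the scatter) stayed within the scatter. Compound 4 is estimated at 2800 nM in this assay, with the expected range running from 1400 nM to 5600 nM.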

Compound 4, half-maximal inhibitory concentration: 1170 nM
Estimate against measurement, compound 4: 2.4-fold (0.38 log units) above; the measured number lies below the stated range.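

In this assay, chloro in place of fluoro on the ring that is part of a fused or bridged system of two rings gives a 2.4-fold lower number from compound 3 to compound 4 (0.38 log units; beyond the scatter), and chloro in place of hydrogen at the same place gives a 2.6-fold lower number from compound 2 to compound 4 (0.41 log units; beyond the scatter), so compound 4 stands modestly apart from both neighbours. Although only the second reading of the fluoro-to-chloro change lies beyond the scatter, the two readings cannot be told apart as a pair: the same change on two cores in this assay, a 1.1-fold lower number (0.02 log units; within the scatter) from compound 1 to compound 2 and a 2.4-fold lower number (0.38 log units; beyond the scatter) from compound 3 to compound 4, 2.3-fold (0.36 log units) apart, within the scatter of two such steps. This shows that the change can give a modest step on one core and none that can be read on the other, but it does not show that the outcome depends on the core or on the place, nor does it show that the change carries unchanged, since the two cases also differ in where the halogen sits and a single pair on each side is too little to settle the matter.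

From the compounds shown here alone, at the place on the fused system, only hydrogen, fluoro and chloro appear, so it remains open how bromo, methoxy, an amine or a carboxylic acid would read there. Going by these compounds, it also remains open whether the step from compound 2 to compound 4 would hold with a group other than chloro on the other ring.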